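The source may report more compounds than this note shows. Statements on the series, on what has been measured and on what is new or still open speak of the compounds shown alone.

Measured so far:
compound 1 `COc1ccc(-c2cc(Cl)cc(C(=O)Nc3nn[nH]n3)n2)cc1` — 100%
compound 2 `COc1cc(C(=O)Nc2nn[nH]n2)nc(-c2ccccc2OC)c1` — 68%

In a functional assay on the whole organism with Rattus norvegicus as the target, at a dose of 3 mg/kg by the oral route (a lower number here means a weaker effect, a higher number a stronger effect of the compound at the dose given), compound 1 gives 100%. In the same assay compound 2 gives 68%, the lowest of the two numbers shown, and its gap to compound 1 lies beyond the scatter of repeated measurements. For the measured compounds named here, no step between compounds that differ in only one place has been measured, so the next compound is approached from compound 2 alone.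

Compound 3 `COc1ccc(-c2cc(OC)cc(C(=O)Nc3nn[nH]n3)n2)cc1` has the same atoms as compound 2, joined differently: 4-methoxyphenyl in place of 2-methoxyphenyl on an aromatic carbon. Going by the values given here, since the only other number in hand, that of compound 1, carries the 4-methoxyphenyl group that enters here, the inhibition of compound 3 is expected to rise in this assay, with a step of a number 17 percentage points higher from compound 2 to compound 3 (beyond the scatter) expected to exceed the scatter. On that basis compound 3 is estimated at 85%, within a range from 60% to 100%.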

Compound 3, a percentage reported as inhibition, in the whole organism at one dose (the size of the read-out at that dose, not a potency): 60%
Beside the measured number, compound 3's estimate is 25 percentage points above it; the range from low to high includes it.
By their numbers in this assay, from the lowest: compounds 3 and 2 (each within the scatter of the next); then compound 1.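

In this assay, 4-methoxyphenyl in place of 2-methoxyphenyl on the aromatic carbon next to the ring nitrogen gives a number 8 percentage points lower from compound 2 to compound 3 (within the scatter), so with a methoxy group on the core, these two aryl groups cannot be told apart at this dose. With 4-methoxyphenyl held fixed, methoxy in place of chloro on an aromatic carbon gives a number 40 percentage points lower from compound 1 to compound 3 (beyond the scatter), so among these compounds the larger step comes from the change of the chloro group, not from the place of the methoxy group on the phenyl ring. Nothing at hand bears on what lies behind either step.

From the compounds shown here alone, whether 2-methoxyphenyl and 4-methoxyphenyl would also match on a core carrying chloro remains open. So does where a compound with an amine, a fluoro group or a longer ethoxy chain on the carbon held by chloro in compound 1 would fall in this assay.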